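This account rests on a few compounds, and the source may have more. Where it says the series, first, only, none or still open, it means among the compounds named here.

Measured compounds:
Compound 1, `FC(F)(F)c1ccc(CSc2nc(Nc3ccccc3C(F)(F)F)c3ccccc3n2)cc1`: in a functional assay on MDA-MB-231 cells (Homo sapiens) for cytotoxicity, read by MTT assay, with a stated time of 72 h (a lower number here means a stronger inhibitor, a higher number a weaker inhibitor), compound 1 gives > 50000 nM, which is a limit of the assay rather than a number.
Compound 2, `COc1ccc(Nc2nc(SCc3ccc(C(F)(F)F)cc3)nc3ccccc23)cc1`: in this assay compound 2 gives 15700 nM.

Going by the values given here, compound 2 is thus the only compound with a numerical value in this assay; the other value shown, that of compound 1, is a limit, as recorded in the limit of > 50000 nM in this assay, at which 1 of the 2 values shown sits. Among the compounds with values here, the single measured step, an at least 3.1-fold lower number from compound 1 to compound 2 (0.50 log units; beyond the scatter), concerns the aryl group on the nitrogen on the aromatic ring and is at least modest.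

Compound 3, `CCOc1ccc(Nc2nc(SCc3ccc(C(F)(F)F)cc3)nc3ccccc23)cc1`, is not yet measured. It differs from compound 2 by methyl in place of hydrogen on a saturated chain carbon bound to an oxygen on an aromatic ring. No measured step touches this part of the molecule: the only step shown changes the aryl group on the nitrogen, not the alkoxy group, and the limit of compound 1 in this assay gives no guidance on a methyl added to the alkoxy chain. With nothing bearing on it, the step of a 1.0-fold lower number from compound 2 to compound 3 (0.02 log units; within the scatter) is expected to lie within the scatter of this assay. Compound 3 is therefore estimated at 15000 nM, with a range from 6000 nM to 40000 nM in this assay.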

Compound 3, half-maximal inhibitory concentration: 23000 nM
Beside the measured number, compound 3's estimate is 1.5-fold (0.19 log units) below it; the measured number falls inside the stated range.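

Methoxy to ethoxy is the only step shown that touches the alkoxy group, and in this assay it gives a 1.5-fold higher number from compound 2 to compound 3 (0.17 log units; within the scatter), so compound 2 and compound 3 cannot be told apart at this position and the added methyl has no resolved effect. The difference from the 2-(trifluoromethyl)phenyl group on the nitrogen also holds with this second alkoxy group, at an at least 2.1-fold lower number from compound 1 to compound 3 (0.33 log units; beyond the scatter), which means that the 4-methoxyphenyl group of compound 2 is not alone in giving a value beyond the scatter from compound 1. The value of compound 1 is a limit of the assay and not a number, so this step gives only a bound on the size of the difference: the limit of > 50000 nM in this assay, at which 1 of the 3 values shown sits.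

The compounds shown leave open whether a longer chain such as propoxy or butoxy on the oxygen would stay within the scatter of the methoxy and ethoxy compounds, or whether it would move the number beyond it. They also leave open what a hydroxyl, an amine or a carboxylic acid would do on that ring in place of the alkoxy group.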